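Removing a chloro group at the assay limit

The source may hold more compounds than are shown below. What is called first, only, known or untested is meant among the compounds shown, and "the series" means these compounds.

Measured in a functional assay on FaDu cells (Homo sapiens) for inhibition, read by sulforhodamine B assay; a lower number here means a stronger inhibitor, a higher number a weaker inhibitor:
Compound 1 `COC(=O)CC/C(C)=C/Cc1c(OC)c(C)c2c(c1OCC#CCN1CCN(Cc3ccc(Cl)cc3)CC1)C(=O)OC2`: > 50000 nM
Compound 2 `COC(=O)CC/C(C)=C/Cc1c(OC)c(C)c2c(c1OCC#CCN1CCN(C(c3ccccc3)c3ccc(Cl)cc3)CC1)C(=O)OC2`: > 50000 nM
Compound 3 `COC(=O)CC/C(C)=C/Cc1c(OC)c(C)c2c(c1OCC#CCN1CCC(C(=O)OC)CC1)C(=O)OC2`: > 50000 nM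

The measured set sits at the limit of > 50000 nM in this assay, at which 3 of the 3 values shown sit. Compound 2 gives > 50000 nM, which is a limit and not a number. Compound 4 `COC(=O)CC/C(C)=C/Cc1c(OC)c(C)c2c(c1OCC#CCN1CCN(C(c3ccccc3)c3ccccc3)CC1)C(=O)OC2` has hydrogen in place of chloro on an aromatic carbon. For the measured compounds named here, the only measured step in this part of the structure is a step that the two limits leave unreadable from compound 1 to compound 2, and it has no readable size. No step beyond the scatter is therefore expected in this assay, and another limit is the likeliest result. The expected change is a number no higher from compound 2 to compound 4 (the limit leaves the size open). For compound 4 the estimate is 50000 nM, with an expected range of 25000 nM to 100000 nM.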

Compound 4, half-maximal inhibitory concentration: > 50000 nM
Compound 4 was reported as a limit; the forecaster's own chance of this, stated with the estimate: 85%; the middle value sits exactly at the limit.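

Compound 4 gives > 50000 nM, a limit and not a number, and compound 2 is also a limit, so no step can be read between them. The compounds shown leave open whether swapping chloro for hydrogen changes inhibition at all: the limit of > 50000 nM in this assay, at which 4 of the 4 values shown sit.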